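The source may hold more compounds than are shown below. What is called first, only, known or untested is meant among the compounds shown, and "the series" means these compounds.

Measured so far in a functional assay on the whole organism with Rattus norvegicus as the target; a lower number here means that less compound is needed, a higher number that more compound is needed for the effect:
Compound 1 `CC/N=C(/NC#N)NCCCCn1nc(-c2ccccc2)ccc1=O` gives 60.7 mg/kg.
Compound 2 `CC/N=C(\S)NCCCn1nc(-c2ccccc2)ccc1=O` gives 88.2 mg/kg.
Compound 3 `CC/N=C(/NC#N)NCCCCCCn1nc(-c2ccccc2)ccc1=O` reaches only a limit of the assay, > 100 mg/kg.

Among the two numbers that were obtained, compound 2 carries the higher one, but its nearest neighbour, compound 1, lies within the usual scatter of it, so the two cannot be ranked against each other. The third value, belonging to compound 3, is a limit and not a number: it sits at the limit of > 100 mg/kg in this assay, at which 1 of the 3 values shown sits.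

The compound still to be measured is compound 4 `CN(C)/C(=N/CCCn1nc(-c2ccccc2)ccc1=O)NC#N`. Compared with compound 2, the change is a group of 8 heavy atoms (4 carbon, 4 nitrogen; no ring) in place of a group of 6 heavy atoms (3 carbon, 2 nitrogen, 1 sulfur; no ring), on a saturated chain carbon, three bonds along the chain from an aromatic nitrogen. Within the data shown here, no step between two measured compounds matches this exchange, so its size must be guessed. Among the measured compounds shown here, the group that enters is close to the one carried by compound 1, whose value of 60.7 mg/kg sits within the scatter of compound 2, and the chain on which it sits is the one of compound 2. On that basis the step of a 1.3-fold lower number from compound 2 to compound 4 (0.10 log units; within the scatter) is expected to stay within the scatter, with no clear direction. Compound 4 is therefore estimated at 70 mg/kg in this assay, with a range from 35 mg/kg to 140 mg/kg.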

Compound 4, dose for half-maximal effect: 93.1 mg/kg
Compound 4: the middle estimate sits 1.3-fold (0.12 log units) below what was measured; the measured number falls inside the stated range.
By their numbers in this assay, from the lowest: compounds 1, 2 and 4 (each within the scatter of the next). At a limit, above all of these: compound 3.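

In this assay, among these compounds, the exchange on a saturated chain carbon, three bonds along the chain from an aromatic nitrogen, gives a 1.1-fold higher number from compound 2 to compound 4 (0.02 log units; within the scatter), the first step that can be read at this place. The group of 8 heavy atoms, with 1 hydrogen-bond donor, 2 hydrogen-bond acceptors and a triple bond, and the group of 6 heavy atoms, with 2 hydrogen-bond donors, 1 hydrogen-bond acceptor and a sulfur, therefore cannot be told apart in this assay on this chain. Nothing measured here says why the two groups cannot be separated.

Compound 3 carries only a limit in this assay, > 100 mg/kg, so what its longer chain does cannot be put as a number. From the compounds shown here alone, whether a urea or a primary amine at this place, on the chain of compound 2, would give a number beyond the scatter of compound 2 remains open.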